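Notes on the step from compound 1 to compound 4

The source may report more compounds than this note shows. Statements on the series, on what has been measured and on what is new or still open speak of the compounds shown alone.

The series shares one core and varies the aryl group on a carbon with a double bond to nitrogen. For the measured compounds named here, compound 1 `CN(C)CCn1cnnc1-c1cc(Oc2ccc(NC(=O)N/N=C/c3ccccc3O[N+](=O)[O-])cc2F)ccn1` carries 2-(nitrooxy)phenyl there and, in a functional assay on HT-29 cells (Homo sapiens) for cytotoxicity, read by MTT assay, with a stated time of 72 h (on this read-out higher numbers stand for weaker inhibition and lower numbers for stronger inhibition), compound 1 gives 950 nM, the lowest of the three numbers measured so far. Compound 2 `COc1cc(/C=N/NC(=O)Nc2ccc(Oc3ccnc(-c4nncn4CCN(C)C)c3)c(F)c2)cc(OC)c1OC` carries 3,4,5-trimethoxyphenyl; in this assay compound 2 gives 3620 nM. Compound 3 `CN(C)CCn1cnnc1-c1cc(Oc2ccc(NC(=O)N/N=C/c3ccc(O)cc3)cc2F)ccn1` carries 4-hydroxyphenyl; in this assay compound 3 gives 1920 nM. The steps away from compound 1 are a 3.8-fold higher number from compound 1 to compound 2 (0.58 log units; beyond the scatter) and a 2.0-fold higher number from compound 1 to compound 3 (0.31 log units; beyond the scatter), so both replacements of the 2-(nitrooxy)phenyl have given higher numbers; between the two replacement groups the step is a 1.9-fold lower number from compound 2 to compound 3 (0.28 log units; within the scatter).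

Compound 4 `CN(C)CCn1cnnc1-c1cc(Oc2ccc(NC(=O)N/N=C/c3ccc(F)cc3Cl)cc2F)ccn1` is not yet measured. It differs from compound 1 in one place: 2-chloro-4-fluorophenyl in place of 2-(nitrooxy)phenyl on a carbon with a double bond to nitrogen. The two measured replacements of the same group bear on this step, and each gave a higher number by a modest amount, so a step of similar size toward a higher number is expected in this assay, estimated as a 2.0-fold higher number from compound 1 to compound 4 (0.30 log units; within the scatter). Compound 4 is therefore expected to give 1900 nM in this assay, with an estimated range from 800 nM to 4500 nM.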

Compound 4, half-maximal inhibitory concentration: 510 nM
Beside the measured number, compound 4's estimate is 3.7-fold (0.57 log units) above it; measured number below the stated range.
By their numbers in this assay, from the lowest: compounds 4 and 1 (each within the scatter of the next); then compounds 3 and 2 (each within the scatter of the next).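

In this assay, for the compounds shown here, the step to the 2-chloro-4-fluorophenyl group (a 1.9-fold lower number from compound 1 to compound 4 (0.27 log units; within the scatter)) is the first replacement of the 2-(nitrooxy)phenyl on a carbon with a double bond to nitrogen that stays within the scatter, so compound 4 and compound 1 cannot be told apart and the nitrooxy group is not needed for a number at this level. The same group also separates compound 4 from the other two aryl groups (4-hydroxyphenyl: a 3.8-fold lower number from compound 3 to compound 4 (0.58 log units; beyond the scatter); 3,4,5-trimethoxyphenyl: a 7.1-fold lower number from compound 2 to compound 4 (0.85 log units; beyond the scatter)), both steps beyond the scatter, so among the four compounds the aryl groups fall into two sets, with compound 1 and compound 4 in one and compound 2 and compound 3 in the other. No measurement at hand gives a reason for this split between the two sets.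

The compounds shown leave open whether one halogen alone would keep an aryl group in the set of compound 1 and compound 4, as a 2-chlorophenyl or a 4-fluorophenyl group on the same carbon would show. They also leave open where an aryl group carrying an amine or a carboxylic acid would fall in this series.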